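A few compounds are considered here, and "the series" means these few. Any claim that something is new, unique, unknown or untested is made for them only; others in the source may bear on it.

Of the compounds shown here, three from one series have been measured in an assay on V79 cells for inhibition of cytochrome P450 11B1, mitochondrial (Homo sapiens), read by HTRF, with a stated time of 1 h; on this read-out higher numbers stand for weaker inhibition and lower numbers for stronger inhibition. Compound 1 `Fc1cc2nc(-c3cccnc3)n(C3CC3)c2cc1F` gives 370 nM in this assay. Compound 2 `N#Cc1cc2c(cc1F)nc(-c1cccnc1)n2C1CC1` gives 117 nM in this assay. For the measured compounds named here, the one change between them is a 3.2-fold lower number from compound 1 to compound 2 (0.50 log units; beyond the scatter). Compound 3 `FC(F)(F)c1ccc2c(c1)nc(-c1cccnc1)n2C1CC1` gives > 10000 nM in this assay, which is a limit of the assay and not a number; it sits at the limit of > 10000 nM in this assay, at which 1 of the 3 values shown sits. Among the three results shown, compound 3 therefore stands apart: compound 1 and compound 2 have measured numbers, while compound 3 has only a limit.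

Compound 4 `Fc1ccc2c(c1)nc(-c1cccnc1)n2C1CC1` has not yet been measured in this assay. It differs from compound 3 by fluoro in place of trifluoromethyl on an aromatic carbon. Going by the values given here, no measured step repeats this change. The step of a 3.2-fold lower number from compound 1 to compound 2 (0.50 log units; beyond the scatter) concerns a different group at a different spot, but it shows that a single change on the shared core can move this assay well beyond the scatter. Because compound 3 gives only > 10000 nM, the true size of the step to compound 4 cannot be read from a known number. Compound 1, which also carries fluoro on the core, gives 370 nM, so a fluoro-bearing compound can return a measured value.

Compound 4 is therefore expected to give a measured number. The expected step is an at least 6.6-fold lower number from compound 3 to compound 4 (0.82 log units; beyond the scatter). The estimate for compound 4 is 1500 nM, with a range from 300 nM to 8000 nM.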

Compound 4, half-maximal inhibitory concentration: 3980 nM
For compound 4 the middle estimate is 2.7-fold (0.42 log units) below the measured one; measured number inside the range.
By their numbers in this assay, from the lowest: compound 2; then compound 1; then compound 4. At a limit, above all of these: compound 3.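

Changing trifluoromethyl to fluoro on this aromatic carbon brings the series back to a measurable number in this assay, giving an at least 2.5-fold lower number from compound 3 to compound 4 (0.40 log units; beyond the scatter). As far as these compounds go, the true size of that step remains unknown, since the result for compound 3 is a limit of the assay and not a number: the limit of > 10000 nM in this assay, at which 1 of the 4 values shown sits. Compound 4 also shows that the extra group on the core of compounds 1 and 2 matters, for hydrogen in place of cyano gives a 34-fold higher number from compound 2 to compound 4 (1.53 log units; beyond the scatter), and hydrogen in place of fluoro gives an 11-fold higher number from compound 1 to compound 4 (1.03 log units; beyond the scatter), whereas the earlier comparison only exchanged one such group for another.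

The compounds shown leave open how other groups on this aromatic carbon, such as a chlorine atom, a methoxy group, an amine or a carboxylic acid, would compare with fluoro and trifluoromethyl. They also leave open whether trifluoromethyl would still leave a compound at the limit if it were paired with the cyano or fluoro group carried by compounds 1 and 2.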